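A few compounds are considered here, and "the series" means these few. Any claim that something is new, unique, unknown or untested is made for them only; others in the source may bear on it.

In an ADME assay on HepG2 cells (Homo sapiens) for cytotoxicity, read by CellTiter-Glo and resazurin assay, with a stated time of 72 h (on this read-out lower numbers stand for an effect already at smaller amounts and higher numbers for an effect only at larger amounts of compound), three compounds of one series have been measured, and all of them end at the limit of the assay. Compound 1 `CC(C)Oc1cccc(-c2ccc(C(=O)N(Cc3cccc(OCCCCCC(=O)O)c3)C(C)C)cc2)c1` gives > 26000 nM, which is a limit rather than a number. Compound 2 `Cc1nnc(-c2cccc(-c3ccc(C(=O)N(Cc4cccc(OCCCCCC(=O)O)c4)C(C)C)cc3)c2)o1` gives > 26000 nM, again a limit. Compound 3 `COc1cc(OC)cc(-c2ccc(C(=O)N(Cc3cccc(OCCCCCC(=O)O)c3)C(C)C)cc2)c1` likewise gives > 26000 nM, a limit. Because all three sit at the limit of > 26000 nM in this assay, at which 3 of the 3 values shown sit, none of the steps between them can be read: a step that the two limits leave unreadable from compound 1 to compound 2, a step that the two limits leave unreadable from compound 1 to compound 3 and a step that the two limits leave unreadable from compound 2 to compound 3 all remain unreadable in size. Compound 3 therefore stands where the other two stand, at a limit and not at a measured number.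

The step to compound 4 `CC(C)N(Cc1cccc(OCCCCCC(=O)O)c1)C(=O)c1ccc(-c2cccc(OC(F)(F)F)c2)cc1` changes one group: 3-(trifluoromethoxy)phenyl in place of 3,5-dimethoxyphenyl on an aromatic carbon. The measured steps that bear on it are the three exchanges at the same aromatic carbon, and none of them showed a readable size, so they give no direction to lean toward. In this assay compound 4 is therefore expected to show no step beyond the scatter, and the step that the limit leaves unreadable from compound 3 to compound 4 is estimated to be flat. Compound 4 is expected to give 40000 nM, with a range from 20000 nM to 100000 nM, and most likely to be reported once more only as a limit.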

Compound 4, half-maximal effective concentration: > 26000 nM
Compound 4 gave a limit, no number; the forecaster's own chance of this, stated with the estimate: 85%; the middle value lies beyond the limit too.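

In this assay compound 4 gives > 26000 nM, again a limit and not a number. Within the data shown here, no step between compound 4 and compound 1, compound 2 or compound 3 can be read, because all four compounds end at the same point: the limit of > 26000 nM in this assay, at which 4 of the 4 values shown sit. The compounds shown leave open how far apart these four lie and whether any exchange on this aromatic carbon would yield a measured number.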